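The compounds below may be only part of what the source reports. "The series", "measured", "known", "first", "only" and "open" are said of these compounds alone.

In an assay on isolated protein for inhibition of Ephrin type-A receptor 2 (Homo sapiens), read by thermal shift assay, tested at 10 uM (a higher number here means that the compound stabilises the target more against heat, a lower number that the compound stabilises the target less), the three measured compounds gave the following numbers:

compound 1 `CCOc1ccc(NC(=O)Nc2cc(C(C)(C)C)nn2-c2ccccc2)cc1`: 1 degrees C
compound 2 `CC(C)(C)c1cc(NC(=O)Nc2ccccc2)n(-c2ccccc2)n1`: 1.6 degrees C
compound 3 `Cc1ccc(-n2nc(C(C)(C)C)cc2NC(=O)Nc2cc(F)cc(F)c2)cc1`: 1.9 degrees C

Compound 3 holds the highest of the three numbers, but its distance to compound 2 and to compound 1 lies within the usual scatter of this assay, so nothing separates the three beyond noise. Among the compounds with values here, the one step between measured compounds that differ in a single place, from compound 1 to compound 2, came to a number 0.60 degrees C higher from compound 1 to compound 2 (within the scatter); it concerns a change on the aryl ring attached to the urea, not the group on the ring nitrogen.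

Compound 4 `CC(C)(C)c1cc(NC(=O)Nc2cc(F)cc(F)c2)n(C(C)(C)C)n1` differs from compound 3 by tert-butyl in place of 4-methylphenyl on an aromatic nitrogen. Within the data shown here, no measured step touches this position, so the only guide is that every change seen so far stayed within the scatter. Compound 4 is therefore expected to move by about a number 0.40 degrees C lower from compound 3 to compound 4 (within the scatter), that is, no step beyond the scatter. The estimate for compound 4 in this assay is 1.5 degrees C, with a range from 0.5 degrees C to 2.5 degrees C.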

Compound 4, shift of the target's melting temperature: 0 degrees C
Beside the measured number, compound 4's estimate is 1.5 degrees C above it; the measured number lies below the stated range.
By their numbers in this assay, from the lowest: compounds 4, 1, 2 and 3 (each within the scatter of the next, the first and the last beyond it).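

In this assay, within the data shown here, the change on the aromatic nitrogen gives the first step beyond the scatter, a number 1.9 degrees C lower from compound 3 to compound 4 (beyond the scatter), whereas the only step available earlier, on the aryl ring attached to the urea, stayed within it. This position is thus the first place in the series where a single change separates two compounds beyond noise: 4-methylphenyl, with its six-membered aromatic ring, gives way to tert-butyl, which has no ring and fewer heavy atoms. Nothing at hand explains this difference.

A single step cannot tell whether the loss of the aromatic ring or the change in the number of heavy atoms matters here. From the compounds shown here alone, what a cyclohexyl, benzyl or pyridyl group on this nitrogen would give remains open, as does whether the step would be the same with another aryl group on the urea.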